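The source may report more compounds than this note shows. Statements on the series, on what has been measured and on what is new or still open speak of the compounds shown alone.

Working notes on the series.

Three compounds in this set have a number in a functional assay on HT cells (Homo sapiens) for antiproliferative activity, read by fluorescence, with a stated time of 72 h; a higher number here means a weaker inhibitor of growth, a lower number a stronger inhibitor of growth. Compound 1 `CC(C)c1n[nH]c2c(NCc3ccc(-c4ccccn4)cc3)nc(SCC(N)=O)nc12` gives 192 nM. Compound 2 `CCC(O)CSc1nc(NCc2ccc(-c3ccccn3)cc2)c2[nH]nc(C(C)C)c2n1` gives 273 nM. Compound 3 `CC(C)c1n[nH]c2c(NCc3ccc(-c4ccccn4)cc3)nc(SCC3CNC(=O)O3)nc12` gives 80 nM. Compound 1 stands second highest of the three, with compound 2 nearest and compound 3 furthest.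

Two steps start from compound 1 and both change the group on the saturated chain carbon bound to the sulfur. Putting 1-hydroxypropyl in place of carbamoyl gives a 1.4-fold higher number from compound 1 to compound 2 (0.15 log units; within the scatter). Putting 2-oxo-1,3-oxazolidin-5-yl in place of carbamoyl gives a 2.4-fold lower number from compound 1 to compound 3 (0.38 log units; beyond the scatter). Between the two variants, a 3.4-fold lower number from compound 2 to compound 3 (0.53 log units; beyond the scatter).

Compound 4 `CC(C)c1n[nH]c2c(NCc3ccc(-c4ccccn4)cc3)nc(SC(CO)C(C)C)nc12` is not yet measured in this assay. Its difference from compound 1 is 1-(hydroxymethyl)-2-methylpropyl in place of carbamoylmethyl on a sulfur. The step from compound 1 to compound 2 is the one that bears on it, since an open-chain hydroxyalkyl group again replaces the carbamoyl-bearing chain, and that step stayed within the scatter. Within the data shown here, no measured step covers the 2-methylpropyl branching. The expectation for compound 4 is therefore a number near that of compound 1, with, if anything, a small move to a higher number, a 1.5-fold higher number from compound 1 to compound 4 (0.16 log units; within the scatter), still inside the scatter. The estimate for compound 4 is 280 nM, with a range from 120 nM to 650 nM.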

Compound 4, concentration for 50% growth inhibition: 980 nM
Compound 4: middle estimate off by 3.5-fold (0.54 log units), on the low side; measured number above the stated range.
By their numbers in this assay, from the lowest: compound 3; then compounds 1 and 2 (each within the scatter of the next); then compound 4.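

In this assay, among these compounds, the 1-(hydroxymethyl)-2-methylpropyl group is the first open-chain hydroxyalkyl group on this sulfur to move the number beyond the scatter, with a 5.1-fold higher number from compound 1 to compound 4 (0.71 log units; beyond the scatter). An open-chain hydroxyalkyl group is therefore not interchangeable with carbamoylmethyl as a class, since the two such chains also separate from each other, with a 3.6-fold higher number from compound 2 to compound 4 (0.56 log units; beyond the scatter); the shape of the chain matters here, not only the presence of a hydroxyl. Among the compounds shown here, the position also spans more than the earlier compounds showed, with a 12-fold higher number from compound 3 to compound 4 (1.09 log units; beyond the scatter), which leaves compound 4 as the weakest inhibitor of growth of the four and compound 3, with its (2-oxo-1,3-oxazolidin-5-yl)methyl group, at the other end.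

No measurement in hand bears on why this chain gives the higher number. Still open, going by these compounds, is whether the branching or the placing of the hydroxyl carries the change, which a 2-hydroxyethyl group, or the same branched chain with an amine in place of the hydroxyl, would help to separate.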